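A Methoxy Group Added on Two Different Cores

A few compounds are considered here, and "the series" means these few. Any claim that something is new, unique, unknown or untested is made for them only; others in the source may bear on it.

Compound 1 `CC(=O)Nc1ccc(O)c(C(=O)/C=C/c2ccccc2)c1` and compound 2 `COc1ccc(/C=C/C(=O)c2cc(NC(C)=O)ccc2O)cc1` share one core, while compound 3 `CC(=O)Nc1ccc2oc(-c3ccccc3)c(O)c(=O)c2c1` and compound 4 `COc1ccccc1-c1oc2ccc(NC(C)=O)cc2c(=O)c1O` share another; the difference between the two cores is not broken down here. In an ADME assay on THP-1 cells (Homo sapiens) for cytotoxicity, read by flow cytometry and propidium iodide staining, with a stated time of 72 h (on this read-out lower numbers stand for stronger inhibition and higher numbers for weaker inhibition), compound 1 gives 85500 nM. Compound 2 carries methoxy in place of hydrogen on an aromatic carbon, and in this assay compound 2 gives 59200 nM, a change of a 1.4-fold lower number from compound 1 to compound 2 (0.16 log units; within the scatter). In this assay compound 3 gives 36000 nM. Compound 4 differs from compound 3 by methoxy in place of hydrogen on an aromatic carbon; here the entering group sits ortho to a large group, whereas in compound 2 it sits para to a large group, so this is the same kind of change, not the same one. For compound 4 a step of a 1.2-fold lower number from compound 3 to compound 4 (0.08 log units; within the scatter) is expected, because the earlier step of a 1.4-fold lower number from compound 1 to compound 2 (0.16 log units; within the scatter) stayed small. The estimate for compound 4 is 30000 nM, between 12000 nM and 75000 nM.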

Compound 4, half-maximal inhibitory concentration: > 125000 nM
Compound 4 ended at the assay's limit; the forecaster's own chance of this, stated with the estimate: 5%; middle value at least 4.1-fold (0.61 log units) away from the limit.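

In this assay the methoxy group gives an at least 3.4-fold higher number from compound 3 to compound 4 (0.54 log units; beyond the scatter), so the small step seen on the core of compound 1 did not carry over to the core of compound 3: the same change on two cores in this assay, a 1.4-fold lower number (0.16 log units; within the scatter) from compound 1 to compound 2 and an at least 3.4-fold higher number (0.54 log units; beyond the scatter) from compound 3 to compound 4, at least 5.0-fold (0.70 log units) apart, beyond the scatter of two such steps

The value of compound 4, > 125000 nM, is a limit of the assay and not a number: the limit of > 125000 nM in this assay, at which 1 of the 4 values shown sits.

The methoxy group sits ortho to a large group in compound 4 but not in compound 2, and the core differs as well, so these compounds cannot show which of the two matters.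

From the compounds shown here alone, it remains open how a methoxy group ortho to a large group would read on the core of compound 1. Also open, going by these compounds, is whether an amine or a carboxylic acid in that place on the core of compound 3 would end at the same limit.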